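Ring swap on the chain carbon of a cyclic amidine series

The source may report more compounds than this note shows. Statements on the series, on what has been measured and on what is new or still open speak of the compounds shown alone.

The shared core is an exocyclic cyclic amidine joined through a saturated chain carbon to an aromatic ring and a second substituent. Compound 1 `Cc1ccc(C(/N=C2\CCCCCN2)C2CC2)c(C)c1` carries a cyclopropyl there; in a functional assay on the whole organism (plasma, strain Sprague-Dawley) with Rattus norvegicus as the target, with a stated time of 2 h, at a dose of 12.5 mg/kg by the oral route (a higher number here means a stronger effect of the compound at the dose given, a lower number a weaker effect), compound 1 gives 14%. Compound 2 `c1ccc(C(/N=C2\CCCCCN2)C2CCC2)cc1` carries a cyclobutyl; in this assay compound 2 gives 14%, level at the digits shown with compound 1, the two together the lowest numbers among the three measured. Compound 3 `c1ccc(C(/N=C2\CCCCCCN2)c2ccco2)cc1` carries a furan-2-yl and a larger amidine ring; in this assay compound 3 gives 22%, and its gap to compound 2 lies within the scatter. Within the data shown here, no two measured compounds differ in only one place, so no single step is known.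

Compound 4 `c1ccc(C(/N=C2\CCCCCN2)c2cccs2)cc1` is the next entry. Relative to compound 2 the change is thiophen-2-yl in place of cyclobutyl on a saturated chain carbon bound to an aromatic carbon and a double-bonded nitrogen. Among the measured compounds shown here, the series so far gives no step for such a change; the measured compounds suggest a small shift, if any, inside the scatter. Compound 4 is expected to give 18% in this assay, with a range of 5% to 34%, meaning an estimated step of a number 4 percentage points higher from compound 2 to compound 4 (within the scatter) from compound 2 to compound 4.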

Compound 4, a percentage reported as inhibition, in the whole organism at one dose (the size of the read-out at that dose, not a potency): 23%
For compound 4 the middle estimate is 5 percentage points below the measured one; measured number inside the range.
By their numbers in this assay, from the lowest: compounds 1, 2, 3 and 4 (each within the scatter of the next).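

The series now has its first step at a single place: thiophen-2-yl in place of cyclobutyl on a saturated chain carbon bound to an aromatic carbon and a double-bonded nitrogen gives a number 9 percentage points higher from compound 2 to compound 4 (within the scatter) in this assay. At this dose, the read-out therefore does not separate a five-membered aromatic ring with one sulfur from a four-membered carbon ring at this position. No measurement shown offers an explanation for this step.

From the compounds shown here alone, whether any group at this carbon moves the read-out beyond the scatter remains open, and a primary amine, a carboxylic acid or a longer alkyl chain there would test this. The separate contributions of amidine ring size and of the methyl groups on the aromatic ring also cannot yet be read.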